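The compounds below may be only part of what the source reports. "The series", "measured", "known", "first", "only" and "open" are said of these compounds alone.

The measured compounds:
compound 1, `CC(O)(CSc1cc(C(F)(F)F)cc(C(F)(F)F)c1)C(=O)Nc1cccc(S(F)(F)(F)(F)F)c1`, 4000 nM;
compound 2, `CC(O)(COc1cccc(S(F)(F)(F)(F)F)c1)C(=O)Nc1ccc(C(F)(F)F)cc1`, 23800 nM;
compound 3, `CC(O)(COc1cccc(C(F)(F)C(F)(F)F)c1)C(=O)Nc1ccc(C(F)(F)F)cc1`, 8100 nM.

All three were tested in a functional assay on VCaP cells (Homo sapiens) for antiproliferative activity, read by propidium iodide staining, with a stated time of 96 h; on this read-out lower numbers stand for stronger inhibition and higher numbers for weaker inhibition. Compound 1 gives the lowest number of the three; compound 3 stands nearest to it and compound 2 furthest. Compound 2 and compound 3 share a core and differ in one place, (a group of 7 heavy atoms (2 carbon, 5 fluorine; no ring) in place of a group of 6 heavy atoms (5 fluorine, 1 sulfur; no ring), on an aromatic carbon). In this assay this change brought a 2.9-fold lower number from compound 2 to compound 3 (0.47 log units; beyond the scatter).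

Compound 4, `CC(O)(CSc1cc(C(F)(F)F)cc(C(F)(F)F)c1)C(=O)Nc1cccc(C(F)(F)C(F)(F)F)c1`, has not yet been measured. It derives from compound 1 by the same change, (a group of 7 heavy atoms (2 carbon, 5 fluorine; no ring) in place of a group of 6 heavy atoms (5 fluorine, 1 sulfur; no ring), on an aromatic carbon), at a place described in the same words as before. The difference between the core of compound 1 and the core of compound 2 is not broken down here, so the two pairs carry the change on different cores. The step in this assay is expected to be a 2.2-fold lower number from compound 1 to compound 4 (0.35 log units; beyond the scatter), a little smaller than the earlier one because the earlier step gave a 2.9-fold lower number from compound 2 to compound 3 (0.47 log units; beyond the scatter) on another core. Compound 4 is therefore estimated at 1800 nM, expected to fall between 700 nM and 5000 nM.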

Compound 4, half-maximal inhibitory concentration: 8600 nM
Estimate against measurement, compound 4: 4.8-fold (0.68 log units) below; measured number above the stated range.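

In this assay, putting 1,1,2,2,2-pentafluoroethyl in place of the group of five fluorine atoms and one sulfur atom gave a 2.2-fold higher number from compound 1 to compound 4 (0.33 log units; beyond the scatter), whereas the same change on the other core gave a 2.9-fold lower number from compound 2 to compound 3 (0.47 log units; beyond the scatter). The change therefore did not carry its direction from one core to the other, and the gap between the two steps is real rather than scatter: the same change on two cores in this assay, a 2.9-fold lower number (0.47 log units; beyond the scatter) from compound 2 to compound 3 and a 2.2-fold higher number (0.33 log units; beyond the scatter) from compound 1 to compound 4, 6.3-fold (0.80 log units) apart, beyond the scatter of two such steps This shows that, in this series, the step measured on one core cannot simply be transferred to another, but it does not show which of the differences between the two cores turns the step around, nor does a single pair on each core give a rule for other cores.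

The compounds shown leave open how the step would run on a core differing from that of compound 1 in a single place. They also leave open where a nitrile or a chlorine atom at the same aromatic carbon would fall relative to compound 1 and compound 4.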